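Chloro gives way to tert-butoxy

The source may report more compounds than this note shows. Statements on the series, on what has been measured and on what is new or still open speak of the compounds shown alone.

In a functional assay on A-431 cells (Homo sapiens) for inhibition, read by MTT assay, with a stated time of 72 h (on this read-out higher numbers stand for weaker inhibition and lower numbers for stronger inhibition), compound 2 `Clc1ccc(-c2nnc(SCCCN3CCN(c4nc5ccccc5s4)CC3)o2)cc1` gives 69200 nM. Among the compounds with values here, compound 1 `CC(C)(C)Oc1ccc(-c2nnc(SCCCN3CCN(c4nc5ccccc5o4)CC3)o2)cc1` gives 65800 nM, and the two numbers lie within the scatter of each other, so compound 2 stands level with the only other compound measured. Compound 3 `CC(C)(C)Oc1ccc(-c2nnc(SCCCN3CCN(c4nc5ccccc5s4)CC3)o2)cc1` departs from compound 2 in a single place: tert-butoxy in place of chloro on an aromatic carbon. Within the data shown here, no measured pair isolates this change, so the expectation rests on little evidence. Compound 1 also carries tert-butoxy and gives 65800 nM, which offers no sign of a large shift. In this assay, no step beyond the scatter is expected in either direction. The estimated 1.2-fold lower number from compound 2 to compound 3 (0.06 log units; within the scatter) is accordingly small. For compound 3 the expected value is 60000 nM, with an estimated range of 25000 nM to 120000 nM.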

Compound 3, half-maximal inhibitory concentration: 67000 nM
For compound 3 the middle estimate is 1.1-fold (0.05 log units) below the measured one; measured number inside the range.
By their numbers in this assay, from the lowest: compounds 1, 3 and 2 (each within the scatter of the next).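

In this assay, the change from chloro to tert-butoxy, on an aromatic carbon para to a large group, now has a measured pair of its own (a 1.0-fold lower number from compound 2 to compound 3 (0.01 log units; within the scatter)), and the step lies within the scatter. Compound 3 also gives a pair for 1,3-benzothiazol-2-yl in place of 1,3-benzoxazol-2-yl on the amine nitrogen in a ring (a 1.0-fold higher number from compound 1 to compound 3 (0.01 log units; within the scatter)), again within the scatter, so neither change separates these compounds in this read-out. Nothing at hand offers an explanation for either result.

The compounds shown leave open whether a different group at this aromatic carbon, such as an amine or a carboxylic acid, would shift the number beyond the scatter. They also leave open what a longer chain in the linker would do.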